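This account rests on a few compounds, and the source may have more. Where it says the series, first, only, none or still open, it means among the compounds named here.

In a functional assay on MCF7 cells (Homo sapiens) for antiproliferative activity, read by sulforhodamine B assay, with a stated time of 72 h (on this read-out higher numbers stand for weaker inhibition and lower numbers for stronger inhibition), compound 1 (`COc1ncc(-c2ccc3ncnc(NCCN(C)C)c3c2)cc1NS(C)(=O)=O`) gives 14700 nM and compound 2 (`CCCCS(=O)(=O)Nc1cc(-c2ccc3ncnc(NCc4ccncc4)c3c2)cnc1OC`) gives 18700 nM, two values that lie within the usual scatter of each other. Within the data shown here, both are methods of stopping short of any clear separation, so compound 1 stands level with the only other measured compound. Compound 3 (`COc1ncc(-c2ccc3ncnc(NCCN(C)C)c3c2)cc1NS(=O)(=O)c1ccc(F)cc1F`) differs from compound 1 in one place, with 2,4-difluorophenyl in place of methyl on a sulfonyl sulfur. Among the measured compounds shown here, no measured pair isolates a change at this place, so the data give no direct size for it in this assay. Neither measured compound carries an aromatic ring on the sulfonyl sulfur, which leaves the forecast uncertain, but a sizeable move toward lower numbers, meaning stronger inhibition, is expected. The expected change is a 9.8-fold lower number from compound 1 to compound 3 (0.99 log units; beyond the scatter). For compound 3 the estimated value is 1500 nM, with an expected range of 150 nM to 12000 nM.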

Compound 3, half-maximal inhibitory concentration: 1020 nM
Compound 3: middle estimate off by 1.5-fold (0.17 log units), on the high side, and the stated range covers the measured number.
By their numbers in this assay, from the lowest: compound 3; then compounds 1 and 2 (each within the scatter of the next).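

In this assay, putting 2,4-difluorophenyl in place of methyl on a sulfonyl sulfur gives a 14-fold lower number from compound 1 to compound 3 (1.16 log units; beyond the scatter). Among these compounds, this is the first direct size for a change at this place, since compound 1 and compound 2 differ in more than one place and could not provide one. It shows that, with the rest of compound 1 unchanged, this larger group with its six-membered aromatic ring is accompanied by stronger inhibition, but nothing shown bears on why.

The compounds shown include no plain phenyl on the sulfonyl sulfur, so the contribution of the ring cannot be separated from that of its two fluorines. They also leave open how a butyl chain or a pyridine ring at this place would read with the rest of compound 1 kept.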